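A few compounds are considered here, and "the series" means these few. Any claim that something is new, unique, unknown or untested is made for them only; others in the source may bear on it.

Of the compounds shown here, three that share one core have been tested in a functional assay on NCI/ADR cells (Homo sapiens) for cytotoxicity, read by sulforhodamine B assay; a lower number here means a stronger inhibitor of growth, a higher number a weaker inhibitor of growth. Compound 1 `CC1=CC[C@@H]([C@@](C)(O)CCCC(C)(C)NC(=S)N/N=C\c2ccccc2)CC1` gives 23800 nM in this assay. Compound 2 `CC1=CC[C@@H]([C@@](C)(O)CCCC(C)(C)NC(=S)N/N=C\c2ccc(C)cc2)CC1` gives 30500 nM, and the step of a 1.3-fold higher number from compound 1 to compound 2 (0.11 log units; within the scatter) shows that a methyl in place of hydrogen on the aromatic carbon made no difference that can be trusted. Going by the values given here, compound 3 `CC1=CC[C@@H]([C@@](C)(O)CCCC(C)(C)NC(=S)N/N=C\c2ccc(O)cc2)CC1` gives 6070 nM, the lowest of the three numbers; the steps of a 3.9-fold lower number from compound 1 to compound 3 (0.59 log units; beyond the scatter) and a 5.0-fold lower number from compound 2 to compound 3 (0.70 log units; beyond the scatter) are both beyond the scatter, so the hydroxy group is the one change so far that clearly lowered the number.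

Compound 4 `CC1=CC[C@@H]([C@@](C)(O)CCCC(C)(C)NC(=S)N/N=C\c2ccc(N(C)C)cc2)CC1` has not yet been measured. The change from compound 3 is dimethylamino in place of hydroxy on an aromatic carbon. The two steps that bear on it are the ones in which hydroxy entered, and both moved the number down by a modest amount. Among the compounds with values here, no measured step replaces hydroxy by dimethylamino, so the only guide is that removing the hydroxy may give back part of that gain. Compound 4 is therefore estimated at 15000 nM, with a range from 5000 nM to 40000 nM. The expected step of a 2.5-fold higher number from compound 3 to compound 4 (0.39 log units; beyond the scatter) is a modest rise.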

Compound 4, concentration for total growth inhibition: > 100000 nM
Compound 4: only a limit was reported; the forecaster's own chance of this, stated with the estimate: 5%; middle value at least 6.6-fold (0.82 log units) from the limit.
By their numbers in this assay, from the lowest: compound 3; then compounds 1 and 2 (each within the scatter of the next). At a limit, above all of these: compound 4.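

The reading for compound 4 in this assay is a limit, not a number: the limit of > 100000 nM in this assay, at which 1 of the 4 values shown sits.

Earlier changes on this aromatic carbon, para to a large group, moved the number by a modest amount at most, whereas dimethylamino in place of hydroxy gives a large step, an at least 16-fold higher number from compound 3 to compound 4 (1.21 log units; beyond the scatter). The rise is also more than a loss of the gain that came with hydroxy, since dimethylamino stands beyond the scatter against hydrogen, an at least 4.2-fold higher number from compound 1 to compound 4 (0.62 log units; beyond the scatter), and against methyl, an at least 3.2-fold higher number from compound 2 to compound 4 (0.51 log units; beyond the scatter).

As far as these compounds go, how far compound 4 lies past its limit stays unknown, so the true size of all three steps remains open. From the compounds shown here alone, it is also open whether a plain amino group or a methoxy group on this carbon would behave more like hydroxy or more like dimethylamino.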